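The source may hold more compounds than are shown below. What is called first, only, known or untested is meant among the compounds shown, and "the series" means these compounds.

Compound 2 `CCOC(=O)c1cc(-c2ccccc2)nn1CC(O)COc1ccccc1[N+](=O)[O-]` gives 30000 nM in a functional assay on A549 cells (Homo sapiens) for inhibition, read by MTT assay, with a stated time of 48 h; a higher number here means a weaker inhibitor, a lower number a stronger inhibitor. That is the lower of the two numbers obtained so far. Compound 1 `CCOC(=O)c1cc(-c2ccccc2)nn1CC(O)COc1ccc([N+](=O)[O-])cc1` gives 48000 nM in this assay. The step of a 1.6-fold lower number from compound 1 to compound 2 (0.20 log units; within the scatter) is within the scatter, so no order between compound 1 and compound 2 is claimed.

Compound 3 `CCOC(=O)c1cc(-c2ccc(Cl)cc2)nn1CC(O)COc1ccccc1[N+](=O)[O-]` is the next member of the series. Relative to compound 2 the change is chloro in place of hydrogen on an aromatic carbon; the same difference, cut one bond further out, reads phenyl to 4-chlorophenyl. Within the data shown here, no measured step touches this phenyl on the shared core. Among the measured compounds shown here, the only measured step, a 1.6-fold lower number from compound 1 to compound 2 (0.20 log units; within the scatter), concerns the nitrophenyl on the oxygen and lies within the scatter, so it gives no direction for the present change. For compound 3 the expected step of no change at the digits printed from compound 2 to compound 3 (within the scatter) is therefore none beyond the scatter. The estimate for compound 3 in this assay is 30000 nM, with a range from 12000 nM to 75000 nM.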

Compound 3, half-maximal inhibitory concentration: 26000 nM
Compound 3: the middle estimate sits 1.2-fold (0.06 log units) above what was measured; the range from low to high includes it.
By their numbers in this assay, from the lowest: compounds 3, 2 and 1 (each within the scatter of the next).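

Among these compounds, the chloro in place of hydrogen on an aromatic carbon, the first measured change on this phenyl of the shared core, gives (a 1.2-fold lower number from compound 2 to compound 3 (0.06 log units; within the scatter)) in this assay. Phenyl and 4-chlorophenyl are therefore not told apart in this assay, and one chlorine atom on this carbon leaves the number of compound 3 within the scatter of that of compound 2. No measurement bears on why this change has so little effect on the number.

Still open, as far as these compounds go, is whether a different group on this aromatic carbon, such as an amine, a carboxylic acid or a methoxy group, would move the number beyond the scatter. Also open, from the compounds shown here alone, is how the series responds at the ethyl ester or the free hydroxyl of the linking chain, for instance with a carboxylic acid in place of the ester.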